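Replacing 2-nitrophenyl with 3,4,5-trimethoxyphenyl in a cytotoxic series

This account rests on a few compounds, and the source may have more. Where it says the series, first, only, none or still open, it means among the compounds named here.

In a functional assay on A549 cells (Homo sapiens) for cytotoxicity, read by MTT assay, with a stated time of 72 h (a lower number here means a stronger inhibitor, a higher number a weaker inhibitor), compound 3 (`COc1cc2ncnc(Nc3ccc(F)c(Cl)c3)c2cc1NC(=O)/C=C/c1ccccc1[N+](=O)[O-]`) gives 33300 nM and stands highest of the three numbers measured, which makes it the weakest of the three. Compound 1 (`COc1ccc(OC)c(/C=C/C(=O)Nc2cc3c(Nc4ccc(F)c(Cl)c4)ncnc3cc2OC)c1`) gives 11200 nM on the same read-out, and compound 2 (`COc1cc(/C=C/C(=O)Nc2cc3c(Nc4ccc(F)c(Cl)c4)ncnc3cc2O[C@H]2CCOC2)cc(OC)c1OC`) gives 4150 nM on it.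

Compound 4 (`COc1cc2ncnc(Nc3ccc(F)c(Cl)c3)c2cc1NC(=O)/C=C/c1cc(OC)c(OC)c(OC)c1`) has not been measured yet. It carries 3,4,5-trimethoxyphenyl in place of 2-nitrophenyl on a double-bonded chain carbon bound to a double-bonded chain carbon.

Going by the values given here, the one measured step at this place is a 3.0-fold higher number from compound 1 to compound 3 (0.47 log units; beyond the scatter) when 2-nitrophenyl replaces 2,5-dimethoxyphenyl, a modest step beyond the scatter. Read in reverse, it points to a lower number when a methoxy-bearing phenyl returns. Compound 2 already holds 3,4,5-trimethoxyphenyl at this place, with a different group on the shared core, and gives 4150 nM in that form. Among the compounds with values here, no measured step isolates that group, so compound 2 serves only as a rough guide.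

A step somewhat larger than the modest one is therefore expected, pointing to a lower number, and the expected step is a 4.2-fold lower number from compound 3 to compound 4 (0.62 log units; beyond the scatter) in this assay on this reasoning. Compound 4 is estimated at 8000 nM (expected range 3000 nM to 20000 nM).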

Compound 4, half-maximal inhibitory concentration: "not active" (no number reported)
Compound 4 has no reported number here; there is nothing to compare the estimate with.
By their numbers in this assay, from the lowest: compound 2; then compound 1; then compound 3.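

In this assay, going by these compounds alone, compound 4 is reported as "not active" without a number, so no step from compound 3 to compound 4 can be read. Nothing available bears on this result. The compounds shown leave open how far 3,4,5-trimethoxyphenyl in place of 2-nitrophenyl shifts the number on this shared core.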